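The source may report more compounds than this note shows. Statements on the series, on what has been measured and on what is new or still open speak of the compounds shown alone.

Measured so far in an ADME assay on microsomes from liver (Rattus norvegicus) for metabolic stability, with a stated time of 10 min, tested at 0.5 uM; a higher number here means that more of the compound is left, a lower number that less of the compound is left:
- compound 1 `CC(C)Cc1ccc(-c2cn(C)c3cc(C(=O)NS(C)(=O)=O)ccc23)cc1`: 94%
- compound 2 `CC(C)COc1ncc(-c2cn(C)c3cc(C(=O)NS(=O)(=O)C4CC4)c(F)cc23)cc1Cl`: 37%
- compound 3 `CC(C)COc1ncc(-c2nn(C)c3cc(C(=O)NS(C)(=O)=O)ccc23)cc1Cl`: 100%

Compound 2 stands lowest of the three in this assay at 37%. Its gaps to the other two both lie beyond the usual scatter, with compound 1 at 94% and compound 3 at 100%.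

Compound 4 `CC(C)COc1ncc(-c2cn(C)c3cc(C(=O)NS(C)(=O)=O)c(F)cc23)cc1Cl` has not yet been measured. It departs from compound 2 at a single place, with methyl in place of cyclopropyl on a sulfonyl sulfur. This turns the (cyclopropylsulfonyl)carbamoyl group into a (methylsulfonyl)carbamoyl group.

For the measured compounds named here, no pair of measured compounds isolates this change, so the evidence is indirect. Compound 1 at 94% and compound 3 at 100% both carry the methylsulfonyl group, but each also differs from compound 2 elsewhere, so their high values cannot be credited to that group alone. A rise beyond the scatter is therefore expected, though with wide uncertainty and probably not all the way to the values of those two compounds. The expected change is a number 31 percentage points higher from compound 2 to compound 4 (beyond the scatter). For compound 4 the estimated value is 68%, with an expected range of 42% to 93%.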

Compound 4, percent of the compound remaining: 85%
Compound 4: the middle estimate sits 17 percentage points below what was measured; the range from low to high includes it.
By their numbers in this assay, from the lowest: compound 2; then compounds 4, 1 and 3 (each within the scatter of the next, the first and the last beyond it).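

In this assay, for the compounds shown here, methyl in place of cyclopropyl on a sulfonyl sulfur gives a number 48 percentage points higher from compound 2 to compound 4 (beyond the scatter), the first step in which this change stands alone. The low number of compound 2 therefore goes with the cyclopropyl group at this place, since the (methylsulfonyl)carbamoyl group on an otherwise identical structure brings compound 4 to 85%. What lies behind this step remains unexplained, as no supporting measurement bears on its cause.

The compounds shown leave open whether the same change would have a comparable effect on the cores of compound 1 and compound 3, whose numbers are already high. They also leave open how ethyl, isopropyl or a longer chain on the sulfonyl sulfur would read in this assay, and so whether the step follows the three-membered ring itself or simply the larger group.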